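A few compounds are considered here, and "the series" means these few. Any claim that something is new, unique, unknown or untested is made for them only; others in the source may bear on it.

Compounds measured so far in an assay on RBL cells for inhibition of Polyunsaturated fatty acid 5-lipoxygenase (Rattus norvegicus); on this read-out higher numbers stand for weaker inhibition and lower numbers for stronger inhibition:

compound 1 `CC(=O)N(O)C(C)c1ccc2oc(-c3ccccc3)cc2c1`: 490 nM
compound 2 `CCOC(=O)CCC(=O)N(O)C(C)c1ccc2oc(-c3ccccc3)cc2c1`: 50 nM

Compound 2 gives the lowest of the two numbers in this assay; its nearest neighbour is compound 1, and the step of a 9.8-fold lower number from compound 1 to compound 2 (0.99 log units; beyond the scatter) lies beyond the scatter. Compound 3 `CC(c1ccc2oc(-c3ccccc3)cc2c1)N(O)C(=O)CO` is the next member of the series and has not been measured. It differs from compound 2 in one place: hydroxy in place of (ethoxycarbonyl)methyl on a saturated chain carbon bound to a carbonyl carbon. Among the compounds with values here, the only measured step that bears on this change is a 9.8-fold lower number from compound 1 to compound 2 (0.99 log units; beyond the scatter), where the (ethoxycarbonyl)methyl group entered in place of hydrogen and the number fell. Compound 3 gives that group up again and carries a hydroxy instead, so the expectation is a return toward the number of compound 1, estimated as a step of a 6.0-fold higher number from compound 2 to compound 3 (0.78 log units; beyond the scatter). Compound 3 is therefore expected to give about 300 nM in this assay, within a range from 100 nM to 1000 nM.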

Compound 3, half-maximal inhibitory concentration: 700 nM
Estimate against measurement, compound 3: 2.3-fold (0.37 log units) below; the measured number falls inside the stated range.
By their numbers in this assay, from the lowest: compound 2; then compounds 1 and 3 (each within the scatter of the next).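

In this assay, hydroxy on the saturated chain carbon bound to a carbonyl carbon does not retain the gain seen with (ethoxycarbonyl)methyl, giving a 14-fold higher number from compound 2 to compound 3 (1.15 log units; beyond the scatter). Set against hydrogen at the same place, hydroxy gives a 1.4-fold higher number from compound 1 to compound 3 (0.15 log units; within the scatter), so these two groups cannot be told apart here, and of the three groups shown only (ethoxycarbonyl)methyl stands apart. Nothing available explains this difference.

The compounds shown do not reveal whether the lower number depends on the ester itself or on the length of the chain; a plain alkyl chain of the same length and the corresponding carboxylic acid would separate these two readings. Also open, as far as these compounds go, is whether the same order of groups holds on any core other than the shared one.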